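Fluoro addition on the dichlorophenyl arm: lipophilicity notes

This account rests on a few compounds, and the source may have more. Where it says the series, first, only, none or still open, it means among the compounds named here.

Compound 1 `CC(C)(C)n1ncc(OCc2nnc(-c3ccc(Cl)cc3)o2)c(Cl)c1=O` gives 3.09 in a physicochemical assay for lipophilicity; a higher number here means a more lipophilic compound, a lower number a more polar compound. Compound 2 `CC(C)(C)n1ncc(OCc2nnc(-c3ccc(Cl)cc3F)o2)c(Cl)c1=O` carries fluoro in place of hydrogen on an aromatic carbon and gives 3.23 in this assay; the step is a number 0.14 log units higher from compound 1 to compound 2 (within the scatter). Compound 3 `CC(C)(C)n1ncc(OCc2nnc(-c3ccc(Cl)cc3Cl)o2)c(Cl)c1=O` differs from compound 1 by chloro in place of hydrogen on an aromatic carbon; in this assay compound 3 gives 3.52, and the steps are a number 0.43 log units higher from compound 1 to compound 3 (beyond the scatter) and a number 0.29 log units higher from compound 2 to compound 3 (within the scatter). Compound 4 `CC(C)(C)n1ncc(OCc2nnc(-c3cc(F)c(Cl)cc3Cl)o2)c(Cl)c1=O` is not yet measured and differs from compound 3 by fluoro in place of hydrogen on an aromatic carbon. Among the measured compounds shown here, this is the same kind of change as the one from compound 1 to compound 2, though the surroundings differ: in compound 2 the fluoro sits ortho to a large group and meta to a chloro group, whereas in compound 4 it sits ortho to a chloro group, meta to a large group and para to a chloro group. A step of about the size of a number 0.14 log units higher from compound 1 to compound 2 (within the scatter) is expected, so a number 0.14 log units higher from compound 3 to compound 4 (within the scatter) is the estimated step in this assay. Compound 4 is estimated at 3.66, between 3.4 and 3.95.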

Compound 4, partition coefficient: 3.36
Beside the measured number, compound 4's estimate is 0.30 log units above it; the whole stated range lies above it.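

In this assay fluoro in place of hydrogen gives a number 0.16 log units lower from compound 3 to compound 4 (within the scatter), and the same kind of change on the 4-chlorophenyl arm gives a number 0.14 log units higher from compound 1 to compound 2 (within the scatter); both steps lie within the scatter, so neither setting shows a readable shift. Among the compounds shown here, the longer steps, a number 0.13 log units higher from compound 2 to compound 4 (within the scatter) and a number 0.27 log units higher from compound 1 to compound 4 (within the scatter), also lie within the scatter, so these two pairs show only that the change stayed small here, not that its size or direction carries to another core. No measurement here bears on why the steps fall as they do.

Still open, going by these compounds, is whether a trifluoromethyl, a nitrile or a carboxylic acid in place of that hydrogen would give a step beyond the scatter. Also open, on these data alone, is how fluoro behaves on a core other than the shared one.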